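The source may report more compounds than this note shows. Statements on the series, on what has been measured and on what is new or still open speak of the compounds shown alone.

Of the compounds shown here, two of the shared core have been measured. Compound 1 `CC(C)(C)c1ccc(CN2C(=O)S/C(=C\c3ccc(N)cc3)C2=O)cc1` gives in a functional assay on L1210 cells (Mus musculus) for cytotoxicity, read by cell counting, with a stated time of 2 days (a higher number here means a weaker inhibitor, a lower number a stronger inhibitor), a value of 94000 nM. Compound 2 `Cc1ccc(CN2C(=O)S/C(=C\c3cccc(N)c3)C2=O)cc1` gives in this assay a value of 176000 nM. Compound 2 holds the higher of the two numbers, but its gap to compound 1 lies within the scatter, so the two cannot be told apart on these data. Compound 3 `Cc1ccc(CN2C(=O)S/C(=C\c3ccc(N)cc3)C2=O)cc1` is not yet measured. It differs from compound 2 only by the (4-aminophenyl in place of 3-aminophenyl on a double-bonded chain carbon bound to a double-bonded ring carbon). Among the measured compounds shown here, no measured pair isolates this change, since compound 1 and compound 2 differ in two places. The two values at hand give no ground to expect a step in this assay beyond the scatter in either direction from compound 2 to compound 3. Compound 3 is therefore estimated at 120000 nM in this assay, with a range of 50000 nM to 300000 nM, an expected step of a 1.5-fold lower number from compound 2 to compound 3 (0.17 log units; within the scatter).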

Compound 3, half-maximal inhibitory concentration: 94000 nM
Beside the measured number, compound 3's estimate is 1.3-fold (0.11 log units) above it, and the stated range covers the measured number.
By their numbers in this assay, from the lowest: compounds 1, 3 and 2 (each within the scatter of the next).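

In this assay, compound 2 and compound 3 now form a pair that isolates 4-aminophenyl in place of 3-aminophenyl on a double-bonded chain carbon bound to a double-bonded ring carbon, and the reading is a 1.9-fold lower number from compound 2 to compound 3 (0.27 log units; within the scatter), so this swap cannot be told apart from repeat scatter. Compound 3 also isolates methyl in place of tert-butyl on an aromatic carbon, with no change at the digits printed from compound 1 to compound 3 (within the scatter), so neither place separates these compounds on the present data. Nothing further is at hand that bears on these results.

The compounds shown leave open whether a carboxylic acid or a hydroxyl group on that phenyl ring would give a step beyond the scatter. They also leave open whether a chlorine atom or a methoxy group in place of the methyl would do so.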